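A Bromophenyl Analogue Tested for Toxicity to Cells

A few compounds are considered here, and "the series" means these few. Any claim that something is new, unique, unknown or untested is made for them only; others in the source may bear on it.

Measured so far:
compound 1, `COc1ccccc1-c1cnc(NC(=O)c2ccc(F)cc2)n1C` — > 100000 nM
compound 2, `COc1ccccc1-c1cnc(NC(=O)c2ncc[nH]2)n1C` — > 50000 nM

In a toxicity assay on THP-1 cells (Homo sapiens) for inhibition (a lower number here means that less compound is tolerated, a higher number that more compound is tolerated), compound 1 gives > 100000 nM, which is a limit of the assay rather than a measured number. Compound 2 gives > 50000 nM in this assay, again a limit. The step that the two limits leave unreadable from compound 1 to compound 2 is therefore not readable in size, since both ends sit at limits (the limit of > 100000 nM in this assay, at which 1 of the 2 values shown sits, and (the limit of > 50000 nM in this assay, at which 1 of the 2 values shown sits)). For the measured compounds named here, compound 1 thus stands only at a limit, and the one further value shown is a limit as well.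

Compound 3, `Cn1c(-c2ccc(Br)cc2)cnc1NC(=O)c1ccc(F)cc1`, differs from compound 1 by 4-bromophenyl in place of 2-methoxyphenyl on an aromatic carbon. Going by the values given here, no measured step touches this part of the molecule; the only measured step, a step that the two limits leave unreadable from compound 1 to compound 2, alters the group on the carbonyl carbon and cannot be sized. The data therefore give no ground for expecting a step beyond the scatter in either direction. Compound 3 is estimated at 100000 nM, within 30000 nM to 300000 nM. The step of a number no higher from compound 1 to compound 3 (the limit leaves the size open) is expected to be none beyond the scatter, with a good chance that only a limit is reported again.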

Compound 3, half-maximal cytotoxic concentration: 46000 nM
The estimate for compound 3 lay 2.2-fold (0.34 log units) above the measured number, and the stated range covers the measured number.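

Exchanging the group on this aromatic carbon of the shared core produces a change that can be read in this assay: 4-bromophenyl in place of 2-methoxyphenyl gives an at least 2.1-fold lower number from compound 1 to compound 3 (0.33 log units; beyond the scatter). For the compounds shown here, this is more than the earlier compounds could show, since the step at the carbonyl carbon cannot be read, and it marks the aryl group at this position as one that can alter how much compound the cells tolerate. Only the lower end of the step's size is known, and the real step may be larger: the limit of > 100000 nM in this assay, at which 1 of the 3 values shown sits.

The change swaps two whole groups, so the compounds shown do not tell whether the lower number goes with the arrival of the bromine or with the loss of the methoxy group. A plain phenyl group at this position would help to separate the two, and a phenyl ring carrying an amine or a carboxylic acid would show how far the tolerated concentration moves with other groups.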